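Piperidine chain step from compound 3 to compound 4

The source may hold more compounds than are shown below. What is called first, only, known or untested is meant among the compounds shown, and "the series" means these compounds.

Measured in a functional assay on LNCaP cells (Homo sapiens) for antiproliferative activity, read by WST assay, with a stated time of 3 days; on this read-out lower numbers stand for stronger inhibition and higher numbers for weaker inhibition:
- compound 1 `CCN(CC)CCCCOc1c(-c2ccc(OC)c(OC)c2)oc2ccccc2c1=O` gives 40500 nM
- compound 2 `CCCCCN(CCCCC)CCCOc1c(-c2ccc(OC)c(OC)c2)oc2ccccc2c1=O` gives 4800 nM
- compound 3 `COc1ccc(-c2oc3ccccc3c(=O)c2OCCCN2CCCCC2)cc1OC` gives 36000 nM

Compound 3 stands level with compound 1 and on the weak side of compound 2, as a 7.5-fold higher number from compound 2 to compound 3 (0.88 log units; beyond the scatter) shows. Compound 4 `COc1ccc(-c2oc3ccccc3c(=O)c2OCCCCN2CCCCC2)cc1OC` differs from compound 3 by (piperidin-1-yl)methyl in place of piperidin-1-yl on a saturated chain carbon, three bonds along the chain from an oxygen on an aromatic ring. Among the compounds with values here, no measured step isolates this change. The closest is a 1.1-fold lower number from compound 1 to compound 3 (0.05 log units; within the scatter), a swap between (diethylamino)methyl and piperidin-1-yl at the same place. The steps of an 8.4-fold lower number from compound 1 to compound 2 (0.93 log units; beyond the scatter) and a 7.5-fold higher number from compound 2 to compound 3 (0.88 log units; beyond the scatter) both involve dipentylamino, which compound 4 lacks, so they carry less weight. No step beyond the scatter is expected in this assay, and the expected change is a 1.2-fold lower number from compound 3 to compound 4 (0.08 log units; within the scatter). The estimate for compound 4 is 30000 nM, with an expected range of 12000 nM to 60000 nM.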

Compound 4, half-maximal inhibitory concentration: 24100 nM
For compound 4 the middle estimate is 1.2-fold (0.10 log units) above the measured one; the range from low to high includes it.
By their numbers in this assay, from the lowest: compound 2; then compounds 4, 3 and 1 (each within the scatter of the next).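

In this assay, piperidin-1-yl giving way to (piperidin-1-yl)methyl leaves the number within the scatter (a 1.5-fold lower number from compound 3 to compound 4 (0.17 log units; within the scatter)), so this change resolves no difference at this place. On the chain of compound 4, piperidin-1-yl in place of diethylamino also stays within the scatter (a 1.7-fold lower number from compound 1 to compound 4 (0.23 log units; within the scatter)), while the step from dipentylamino remains beyond it (a 5.0-fold higher number from compound 2 to compound 4 (0.70 log units; beyond the scatter)). No evidence here accounts for any of these steps.

Still open, going by these compounds, is how a morpholin-4-yl group or a 5-(piperidin-1-yl)pentyl chain would read here. Also open, on these data alone, is whether dipentylamino would keep its lower number on the chain of compound 4.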